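This account rests on a few compounds, and the source may have more. Where it says the series, first, only, none or still open, it means among the compounds named here.

Among the measured compounds shown here, in a functional assay on HeLa cells (Homo sapiens) for cytotoxicity, read by MTT assay, with a stated time of 72 h (a lower number here means a stronger inhibitor, a higher number a weaker inhibitor), compound 1 `COc1ccc(/C=C/C(=O)Nc2cc(C(=O)c3cc(OC)c(OC)c(OC)c3)ccc2OC)cc1` gives 10700 nM and compound 2 `COc1cccc(/C=C/C(=O)Nc2cc(C(=O)c3cc(OC)c(OC)c(OC)c3)ccc2OC)c1` gives 3100 nM, the lower of the two numbers so far. For the measured compounds named here, the only measured step is a 3.5-fold lower number from compound 1 to compound 2 (0.54 log units; beyond the scatter), a change of a different kind from the one now considered. Compound 3 `COc1cc(/C=C/C(=O)Nc2cc(C(=O)c3cc(OC)c(OC)c(OC)c3)ccc2OC)ccc1F` differs from compound 2 by fluoro in place of hydrogen on an aromatic carbon. Going by the values given here, no measured step addresses a fluoro entering at such a place, so no step beyond the scatter is expected in this assay, though the range is kept wide. Compound 3 is estimated at 2500 nM, between 700 nM and 9000 nM, an expected step of a 1.2-fold lower number from compound 2 to compound 3 (0.09 log units; within the scatter).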

Compound 3, half-maximal inhibitory concentration: 13600 nM
Compound 3: the middle estimate sits 5.4-fold (0.74 log units) below what was measured; the measured number lies above the stated range.
By their numbers in this assay, from the lowest: compound 2; then compounds 1 and 3 (each within the scatter of the next).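

In this assay fluoro on the aromatic carbon ortho to a methoxy group and para to a large group gives a 4.4-fold higher number from compound 2 to compound 3 (0.64 log units; beyond the scatter) and so removes the advantage of compound 2 at this position. Set against the 4-methoxyphenyl group, the 4-fluoro-3-methoxyphenyl group gives a 1.3-fold higher number from compound 1 to compound 3 (0.10 log units; within the scatter) and leaves the two compounds level. No measurement shown here accounts for the effect of fluoro at this carbon.

From the compounds shown here alone, whether this carbon tolerates only hydrogen remains open. Chloro, methyl or an amine there could show whether the drop is specific to fluoro.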